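The compounds below may be only part of what the source reports. "The series", "measured", "known", "first", "only" and "open" are said of these compounds alone.

Of the compounds shown here, three that share one core have been measured in a functional assay on HepG2 cells (Homo sapiens) for antiproliferative activity, read by MTT assay, with a stated time of 48 h; on this read-out lower numbers stand for stronger inhibition and higher numbers for weaker inhibition. Compound 1 `COc1ccc(C2OC(c3ccc4ccccc4c3)=NN2C(C)=O)cc1` gives 3.6 ug/mL, compound 2 `CC(=O)N1N=C(c2ccc3ccccc3c2)OC1c1cccc(Br)c1` gives 1.68 ug/mL, and compound 3 `CC(=O)N1N=C(c2ccc3ccccc3c2)OC1c1ccccc1Cl` gives 4.32 ug/mL. Compound 2 thus holds the lowest number of the three, and both gaps to it lie beyond the scatter: the step from compound 1 to compound 2 was a 2.1-fold lower number from compound 1 to compound 2 (0.33 log units; beyond the scatter), with 3-bromophenyl in place of 4-methoxyphenyl on a saturated ring carbon, and the step from compound 2 to compound 3 was a 2.6-fold higher number from compound 2 to compound 3 (0.41 log units; beyond the scatter), with 2-chlorophenyl in place of 3-bromophenyl. Between compound 1 and compound 3 the step was only a 1.2-fold higher number from compound 1 to compound 3 (0.08 log units; within the scatter).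

Compound 4 `CC(=O)N1N=C(c2ccc3ccccc3c2)OC1c1cccc(F)c1` keeps the core and the ring of compound 2 but carries a different halogen: fluoro in place of bromo on an aromatic carbon. Going by the values given here, no measured step exchanges one halogen for another at the same place, so the bearing of the data is indirect. Both steps leading away from the bromo-bearing ring raised the number, and compound 2 has no measured neighbour with a lower number, so a modest rise is expected rather than a fall. Compound 4 is therefore estimated at 2.8 ug/mL, with a likely range from 1.4 ug/mL to 5.6 ug/mL. The expected step from compound 2 to compound 4 is a 1.7-fold higher number from compound 2 to compound 4 (0.22 log units; within the scatter).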

Compound 4, half-maximal inhibitory concentration: 1.86 ug/mL
Beside the measured number, compound 4's estimate is 1.5-fold (0.18 log units) above it; measured number inside the range.
By their numbers in this assay, from the lowest: compounds 2, 4, 1 and 3 (each within the scatter of the next, the first and the last beyond it).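

Going by these compounds alone, this is the first exchange of one halogen for another at a single place, on an aromatic carbon meta to a large group, and in this assay fluoro in place of bromo gives a 1.1-fold higher number from compound 2 to compound 4 (0.04 log units; within the scatter), so this assay does not tell these two halogens apart here. The 3-fluorophenyl compound also shows a 2.3-fold lower number from compound 3 to compound 4 (0.37 log units; beyond the scatter) and a 1.9-fold lower number from compound 1 to compound 4 (0.29 log units; within the scatter), which means that only the first of these two steps can be read as a real difference, even though compound 2 and compound 4 cannot be separated from each other. Nothing available explains why bromo and fluoro read alike at this place.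

Because 2-chlorophenyl and 3-fluorophenyl differ in both the halogen and where it sits, the shown compounds cannot say which of the two matters. As far as these compounds go, it also stays open whether this place tolerates only halogens, or whether a chloro, a nitrile, an amine or a carboxylic acid there would keep the number equally low.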